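This account rests on a few compounds, and the source may have more. Where it says the series, first, only, none or still open, it means among the compounds named here.

In a functional assay on cells (Neutrophil, Homo sapiens) for inhibition, with stated times of 5 min, 10 min and 3 min (a higher number here means a weaker inhibitor, a lower number a stronger inhibitor), compound 2 `COc1ccc(/C=C/C(=O)c2ccco2)c(CN2CCCCC2)c1O` gives 4180 nM and compound 1 `COc1ccc(/C=C/C(=O)c2cccs2)c(CN2CCCCC2)c1O` gives 8320 nM, so the two values lie within the scatter of each other. Compound 3 `COc1ccc(/C=C/C(=O)c2cccnc2)c(CN2CCCCC2)c1O` differs from compound 2 in one place: pyridin-3-yl in place of furan-2-yl on a carbonyl carbon. Among the measured compounds shown here, the only measured step at this carbonyl carbon, a 2.0-fold lower number from compound 1 to compound 2 (0.30 log units; within the scatter), stays within the scatter, but no measured step brings in pyridin-3-yl. This one step is thin support, so a wide range is kept, and no change beyond the scatter is expected in this assay. The expected step is a 1.2-fold higher number from compound 2 to compound 3 (0.08 log units; within the scatter). For compound 3, the estimated value is 5000 nM, with a range of 1800 nM to 14000 nM.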

Compound 3, half-maximal inhibitory concentration: 13000 nM
The estimate for compound 3 lay 2.6-fold (0.41 log units) below the measured number; measured number inside the range.
By their numbers in this assay, from the lowest: compounds 2, 1 and 3 (each within the scatter of the next, the first and the last beyond it).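

In this assay, among the compounds shown here, a step of a 3.1-fold higher number from compound 2 to compound 3 (0.49 log units; beyond the scatter) is the first at this carbonyl carbon to go beyond the scatter, though only modestly. A step of a 1.6-fold higher number from compound 1 to compound 3 (0.19 log units; within the scatter) stays within the scatter, so pyridin-3-yl is separated from furan-2-yl but not from thiophen-2-yl. Nothing at hand bears on the reason for this difference.

Open, on these data alone, is how phenyl or pyridin-4-yl on this carbonyl carbon would compare with these three heteroaryl groups. The compounds shown also leave every other place on the shared core unchanged.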